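The compounds below may be only part of what the source reports. "The series", "measured", "known", "first", "only" and "open" are said of these compounds alone.

Notes on the series. Two nucleoside analogues have been run in an ADME assay on L1210/0 cells (Mus musculus) for cytotoxicity, with a stated time of 48 h; on this read-out higher numbers stand for weaker inhibition and lower numbers for stronger inhibition. Compound 1 `Nc1ncnc2c1ncn2[C@@H]1O[C@H](/C=C/F)[C@H](O)[C@@H]1O` is one of them. In this assay compound 1 gives only a limit, > 200000 nM. The second is compound 2 `O=c1[nH]c(=O)n([C@H]2C[C@H](O)[C@@H](CO)O2)cc1C#CCO`. In this assay compound 2 likewise gives only a limit, > 200000 nM. Compound 2 therefore stands at the upper bound of what the assay reports, together with compound 1, as shown by the limit of > 200000 nM in this assay, at which 2 of the 2 values shown sit; no measured step separates the two, and each shows only that no inhibition was reached in the tested range.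

The next compound is compound 3 `CC(C)(C)C#Cc1cn([C@H]2C[C@H](O)[C@@H](CO)O2)c(=O)[nH]c1=O`, which differs from compound 2 in one place: tert-butyl in place of hydroxymethyl on a triple-bonded carbon. Going by the values given here, no measured step covers a change of this kind, so there is nothing to set its size from. The expected step is a number no higher from compound 2 to compound 3 (the limit leaves the size open), none beyond the scatter. Compound 3 is estimated at 200000 nM in this assay, with a range from 50000 nM to 400000 nM, most likely again reported only as a limit.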

Compound 3, half-maximal inhibitory concentration: > 200000 nM
Compound 3 gave a limit, no number; the forecaster's own chance of this, stated with the estimate: 85%; the middle value lies on the limit itself.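

In this assay, going by these compounds alone, compound 3 gives only a limit (> 200000 nM), so no step from compound 2 to compound 3 can be read: the limit of > 200000 nM in this assay, at which 3 of the 3 values shown sit. The compounds shown leave open what structural change, if any, would bring a value within the range this read-out can report.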